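Compound 3 to compound 4: exchanging a substituent

The compounds below may be only part of what the source reports. "The series", "measured", "known", "first", "only" and "open" are said of these compounds alone.

In a functional assay on K562 cells (Homo sapiens) for cytotoxicity, read by fluorescence, with a stated time of 72 h (on this read-out higher numbers stand for weaker inhibition and lower numbers for stronger inhibition), compound 1 `CSc1nc(NCc2ccc(-c3ccccn3)cc2)c2[nH]nc(C(C)C)c2n1` gives 778 nM and compound 2 `CC(C)c1n[nH]c2c(NCc3ccc(-c4ccccn4)cc3)nc(S(C)(=O)=O)nc12` gives 640 nM, and a 1.2-fold lower number from compound 1 to compound 2 (0.08 log units; within the scatter) shows that methylsulfonyl in place of methylsulfanyl makes no difference beyond the scatter. Compound 3 `CC(C)c1n[nH]c2c(NCc3ccc(-c4ccccn4)cc3)nc(N3CCCCC3CCO)nc12` gives 165 nM, the lowest number of the three, and it stands beyond the scatter from both others.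

Compound 4 `CC(C)c1n[nH]c2c(NCc3ccc(-c4ccccn4)cc3)nc(NCC(N)CO)nc12` has not yet been measured. Relative to compound 3 it carries a group of 6 heavy atoms (3 carbon, 2 nitrogen, 1 oxygen; no ring) in place of a group of 9 heavy atoms (7 carbon, 1 nitrogen, 1 oxygen; one six-membered non-aromatic ring with 1 hetero atom), on an aromatic carbon, on the carbon between two ring nitrogen atoms.

Within the data shown here, two measured steps bear on this carbon: a 4.7-fold lower number from compound 1 to compound 3 (0.67 log units; beyond the scatter) and a 3.9-fold lower number from compound 2 to compound 3 (0.59 log units; beyond the scatter). Both are modest, and both introduce the group that compound 4 loses. Among the measured compounds shown here, neither shows what happens when 2-(2-hydroxyethyl)piperidin-1-yl is itself replaced, and no measured compound carries a ringless group of this kind at this carbon. As far as these compounds go, the direction of the change therefore remains open, and the modest size of those two steps argues against expecting a large move.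

The expected change is small, a 1.1-fold lower number from compound 3 to compound 4 (0.04 log units; within the scatter), with no shift beyond the scatter anticipated in this assay. For compound 4 the estimated value is 150 nM, with an expected range of 45 nM to 500 nM.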

Compound 4, half-maximal inhibitory concentration: 700 nM
Estimate against measurement, compound 4: 4.7-fold (0.67 log units) below, outside the stated range (above it).
By their numbers in this assay, from the lowest: compound 3; then compounds 2, 4 and 1 (each within the scatter of the next).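

In this assay, among these compounds, this is the first measured replacement of 2-(2-hydroxyethyl)piperidin-1-yl on the carbon between two ring nitrogen atoms, and the ringless group does not hold the number of compound 3, with a 4.2-fold higher number from compound 3 to compound 4 (0.63 log units; beyond the scatter). The other two steps, a 1.1-fold higher number from compound 2 to compound 4 (0.04 log units; within the scatter) and a 1.1-fold lower number from compound 1 to compound 4 (0.05 log units; within the scatter), leave compound 4 indistinguishable from the methylsulfonyl and methylsulfanyl compounds, so among these four only compound 3 stands apart, and a group containing both nitrogen and oxygen is not enough at this position to match it. No measurement on hand accounts for the step from the piperidine group to the ringless group.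

Still open, as far as these compounds go, is whether the lower number of compound 3 depends on the six-membered ring, on the 2-hydroxyethyl chain or on the two together. Plain piperidin-1-yl, with no chain, and a ringless 2-hydroxyethylamino group on this carbon would separate those parts, while a morpholine would test a second ring atom other than carbon.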